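A phenyl swap at the limit of the assay

The source may hold more compounds than are shown below. What is called first, only, known or untested is meant among the compounds shown, and "the series" means these compounds.

Measured in a functional assay on CUTLL1 cells (Homo sapiens) for inhibition, read by resazurin assay, with a stated time of 48 h, in the absence of a further agent; a lower number here means that less compound is needed, a higher number that more compound is needed for the effect:
Compound 1 `Nc1ncc(-c2ccncc2-c2ccccc2)c(C2CC2)n1`: > 100000 nM
Compound 2 `CC(C)c1nc(N)ncc1-c1ccncc1`: > 100000 nM

Neither entry is a true number, as the limit of > 100000 nM in this assay, at which 2 of the 2 values shown sit, shows. Compound 2 stands at > 100000 nM, which is a limit of the assay. Among the compounds with values here, no two measured compounds differ in just one place, so no measured step is available as a guide.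

The next compound, compound 3 `Nc1ncc(-c2ccncc2)c(-c2ccccc2)n1`, carries phenyl in place of isopropyl on an aromatic carbon, next to the ring nitrogen (phenyl in place of isopropyl on an aromatic carbon). Compound 1 also carries a phenyl group and still gives > 100000 nM, again a limit. Little change is therefore expected in this assay, with any shift most likely toward less compound being needed. The expected change is an at least 1.2-fold lower number from compound 2 to compound 3 (0.09 log units; that floor lies within the scatter). For compound 3 the estimate is 80000 nM, with an expected range from 25000 nM to 100000 nM.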

Compound 3, half-maximal effective concentration: > 100000 nM
Compound 3 ended at the assay's limit; the forecaster's own chance of this, stated with the estimate: 70%; middle value at least 1.2-fold (0.09 log units) away from the limit.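

Compound 2 and compound 3 both sit at a limit rather than at a true number, so the step from isopropyl to phenyl between them cannot be read: the limit of > 100000 nM in this assay, at which 3 of the 3 values shown sit.

The compounds shown leave open how compound 2 and compound 3 truly compare, and which change to the shared core would give a true number in this assay.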